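Pyrazinylmethyl ether of the trimethoxy cinnamamide

A few compounds are considered here, and "the series" means these few. Any claim that something is new, unique, unknown or untested is made for them only; others in the source may bear on it.

Compound 3 `COc1cc(CNC(=O)/C=C/c2cc(OC)c(OC)cc2OC)ccc1O` gives the lowest number of the three measured in a functional assay on SH-SY5Y cells (Homo sapiens) for cytotoxicity, read by MTT assay, with stated times of 24 h and 4 h (a higher number here means that more compound is needed for the effect, a lower number that less compound is needed), at 2410 nM. Compound 2 `COc1ccc(/C=C/C(=O)NCc2ccc(OCc3nc(C)c(C)nc3C)c(OC)c2)cc1` gives 5050 nM in this assay, and compound 1 `COc1cc(CNC(=O)/C=C/c2ccccc2O)ccc1OCc1nc(C)c(C)nc1C` gives 5300 nM; both stand above compound 3 by margins beyond the scatter. Among the measured compounds shown here, the only single-point step measured, a 1.0-fold lower number from compound 1 to compound 2 (0.02 log units; within the scatter), concerns the aryl group on the double-bonded chain and leaves the ether untouched.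

Compound 4 `COc1cc(OC)c(OC)cc1/C=C/C(=O)NCc1ccc(OCc2nc(C)c(C)nc2C)c(OC)c1` differs from compound 3 by (3,5,6-trimethylpyrazin-2-yl)methyl in place of hydrogen on an oxygen on an aromatic ring. For the measured compounds named here, no measured pair isolates this change. Going by the values given here, compounds 1 and 2 carry the same ether, but each also differs from compound 3 in the aryl group on the chain, so their numbers show only that both ether-bearing compounds sit higher than compound 3 in this assay, beyond the scatter, without separating the two contributions. Taken as loose guidance, a rise toward the numbers of the ether-bearing pair appears more likely than a fall. The expected step is a 1.7-fold higher number from compound 3 to compound 4 (0.22 log units; within the scatter), toward a higher number, with wide uncertainty. Compound 4 is therefore estimated at 4000 nM, with a range from 1500 nM to 10000 nM.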

Compound 4, half-maximal effective concentration: 3620 nM
The estimate for compound 4 lay 1.1-fold (0.04 log units) above the measured number; the measured number falls inside the stated range.
By their numbers in this assay, from the lowest: compounds 3, 4, 2 and 1 (each within the scatter of the next, the first and the last beyond it).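

Working notes on the ether position: in this assay, the pair now isolates the exchange of hydroxy for (3,5,6-trimethylpyrazin-2-yl)methoxy, and a 1.5-fold higher number from compound 3 to compound 4 (0.18 log units; within the scatter) is a step within the scatter, so this change on an oxygen on an aromatic ring is not resolved from no effect. With the ether held constant, the aryl group on the double-bonded chain can also be read on its own: a 1.4-fold lower number from compound 2 to compound 4 (0.14 log units; within the scatter) and a 1.5-fold lower number from compound 1 to compound 4 (0.17 log units; within the scatter) are likewise both within the scatter, so 2,4,5-trimethoxyphenyl is not separated from 4-methoxyphenyl or from 2-hydroxyphenyl. Among these four compounds, therefore, no step confined to one place lies beyond the scatter, and neither the ether nor the aryl group alone is shown to shift the number in this assay.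

Still open, from the compounds shown here alone, is whether another group on that oxygen, such as an amine, a carboxylic acid or a longer chain carrying the pyrazine, would give a step beyond the scatter. No measurement is available that bears on why the numbers in this series fall as they do.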